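Hydroxyphenyl Variants in a Cyclohexanone Bis-arylidene Series

The source may report more compounds than this note shows. Statements on the series, on what has been measured and on what is new or still open speak of the compounds shown alone.

The series is followed in a functional assay on HT-1080 cells (Homo sapiens) for cytotoxicity, read by MTT assay, with a stated time of 72 h; a lower number here means a stronger inhibitor, a higher number a weaker inhibitor. Compound 1 `COc1cccc(/C=C2\CCC/C(=C\c3ccc(O)cc3)C2=O)c1OC` reports only the assay limit, > 20000 nM. Compound 2 `COc1cccc(/C=C2\CCC/C(=C\c3cc(OC)c(OC)c(OC)c3)C2=O)c1OC` gives 2300 nM, and compound 3 `COc1ccc(/C=C2\CCC/C(=C\c3cccc(Br)c3)C2=O)cc1OC` gives 5200 nM. Among the two numerical values, compound 3 stands highest; the nearest value is that of compound 2, which is lower by a margin beyond the scatter, and the remaining entry is a limit. The limit reached by compound 1 is noted as the limit of > 20000 nM in this assay, at which 1 of the 3 values shown sits.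

The next compound, compound 4 `COc1ccc(/C=C2\CCC/C(=C\c3ccc(O)c(Cl)c3)C2=O)cc1OC`, differs from compound 3 by 3-chloro-4-hydroxyphenyl in place of 3-bromophenyl on a double-bonded chain carbon bound to a double-bonded ring carbon.

Among the compounds with values here, no measured pair isolates this change. Within the data shown here, what can be read from the series is that the one compound carrying a hydroxyphenyl, compound 1, gives only the assay limit > 20000 nM, while compound 3 with a halogen alone sits at a measurable number. Compound 4 carries both the hydroxyl and a halogen, so the step is expected to go toward weaker inhibition, likely beyond the scatter, with a real chance that only a limit is returned. Compound 4 is accordingly estimated at 11000 nM, within 4500 nM to 25000 nM, an expected step of a 2.1-fold higher number from compound 3 to compound 4 (0.33 log units; beyond the scatter).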

Compound 4, half-maximal inhibitory concentration: 7600 nM
For compound 4 the middle estimate is 1.4-fold (0.16 log units) above the measured one; the range from low to high includes it.
By their numbers in this assay, from the lowest: compound 2; then compounds 3 and 4 (each within the scatter of the next). At a limit, above all of these: compound 1.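

In this assay, the step of a 1.5-fold higher number from compound 3 to compound 4 (0.16 log units; within the scatter) shows that 3-chloro-4-hydroxyphenyl can take the place of 3-bromophenyl on a double-bonded chain carbon bound to a double-bonded ring carbon without a change beyond the scatter. The earlier compounds shown here could not show this, since none of them formed a one-place pair, and the only one carrying a hydroxyphenyl returned no number; compound 4 carries a hydroxyl on this ring and still gives a measurable value. Compound 1 remains the only compound at a limit, and that entry is a limit rather than a number: the limit of > 20000 nM in this assay, at which 1 of the 4 values shown sits.

The step exchanges bromine for chlorine and adds a hydroxyl in a single move, so the compounds shown cannot separate what each of these contributes, and compounds 1 and 2 differ from compounds 3 and 4 in more than one place, which leaves no step to them that can be read. As far as these compounds go, how an amine or a carboxylic acid on the ring at this place would read in this assay also stays open.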